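A few compounds are considered here, and "the series" means these few. Any claim that something is new, unique, unknown or untested is made for them only; others in the source may bear on it.

Measured in an ADME assay on H1-HeLa cells (Homo sapiens) for cytotoxicity, read by MTT assay, with a stated time of 3 days; a higher number here means that more compound is tolerated, a lower number that less compound is tolerated:
- compound 1 `CCOC(=O)c1cc2ccc(Oc3ccnc(C(=O)NC)c3)cc2s1`: > 100000 nM (a limit of the assay)
- compound 2 `CCOC(=O)c1sc2cc(Oc3ccnc(C(=O)NC)c3)ccc2c1C`: 50900 nM

As far as these compounds go, compound 1 stands at > 100000 nM, which is a limit and not a number, so its true place on the scale is unknown. Compound 3 `CCOC(=O)c1cc2ccc(Oc3ccnc(C(=O)NC)c3)c(Cl)c2s1` is compound 1 with one change, chloro in place of hydrogen on an aromatic carbon, ortho to a fused ring. Among the measured compounds shown here, only one measured step bears on this, and it involves a different group, methyl in place of hydrogen on an aromatic carbon: an at least 1.9-fold lower number from compound 1 to compound 2 (0.29 log units; that floor lies within the scatter). On that single step, at most a small downward move is expected in this assay, and a result still at the limit would not surprise. The expected size is an at least 1.4-fold lower number from compound 1 to compound 3 (0.15 log units; that floor lies within the scatter). For compound 3 the estimated value is 70000 nM, with an expected range from 30000 nM to 100000 nM.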

Compound 3, half-maximal cytotoxic concentration: > 100000 nM
Compound 3: a limit, no number; the forecaster's own chance of this, stated with the estimate: 40%; middle value at least 1.4-fold (0.15 log units) away from the limit.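

In this assay compound 3 gives > 100000 nM, which is a limit and not a number, and compound 1 also stands at a limit, so no step between them can be read: the limit of > 100000 nM in this assay, at which 2 of the 3 values shown sit.

The compounds shown leave open whether chloro in place of hydrogen shifts tolerance at all.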